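The source may hold more compounds than are shown below. What is called first, only, known or untested is meant among the compounds shown, and "the series" means these compounds.

Of the compounds shown here, two built on a shared core have been measured in an in vitro functional assay on HEK285-7 cells for antagonist activity at prostaglandin D2 receptor 2 (Homo sapiens), read by BRET and beta-arrestin recruitment; on this read-out higher numbers stand for weaker inhibition and lower numbers for stronger inhibition. Compound 1 `O=C(O)Cc1sc(C(c2ccccc2)c2ccccc2)nc1-c1cccc(F)c1` gives 29 nM in this assay, whereas compound 2 `NS(=O)(=O)c1cccc(-c2nc(C(c3ccc(F)cc3)c3ccc(F)cc3)sc2CC(=O)O)c1` gives 710 nM, the higher of the two numbers and well beyond the usual scatter from compound 1. Compound 3 `COc1cc(-c2nc(C(c3ccc(F)cc3)c3ccc(F)cc3)sc2CC(=O)O)ccn1` has not been measured. It differs from compound 2 in one place: 2-methoxypyridin-4-yl in place of 3-sulfamoylphenyl on an aromatic carbon. Going by the values given here, no single-change step between measured compounds is available, so the size of this step cannot be read directly from the data, and compound 1 differs from compound 2 in more than one place. Still, compound 1, which carries no 3-sulfamoylphenyl group, stands at 29 nM, far below compound 2. On that basis a move toward lower numbers is expected, about a 4.7-fold lower number from compound 2 to compound 3 (0.68 log units; beyond the scatter). Compound 3 is estimated at 150 nM in this assay, likely between 40 nM and 600 nM.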

Compound 3, half-maximal inhibitory concentration: 380 nM
Beside the measured number, compound 3's estimate is 2.5-fold (0.40 log units) below it; measured number inside the range.
By their numbers in this assay, from the lowest: compound 1; then compounds 3 and 2 (each within the scatter of the next).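

In this assay, replacing 3-sulfamoylphenyl with 2-methoxypyridin-4-yl on this aromatic carbon gives a 1.9-fold lower number from compound 2 to compound 3 (0.27 log units; within the scatter). Going by these compounds alone, this is the first direct reading at this position: the change removes a hydrogen-bond donor, shortens the group by two heavy atoms and puts a hetero atom into the six-membered ring, yet the two compounds cannot be told apart on this read-out. Nothing measured here accounts for that result.

Steps linking compound 1 to compound 2 or compound 3 cannot be read, as it differs from each in more than one place. On these data alone, it also remains open whether a 2-aminopyridin-4-yl group, which keeps the hetero atom in the ring and adds an amine, would read differently at this position.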